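Removing the methyl from a methoxy group on an aryl iminosugar

A few compounds are considered here, and "the series" means these few. Any claim that something is new, unique, unknown or untested is made for them only; others in the source may bear on it.

Of the compounds shown here, three sharing one core have been measured in an assay on isolated protein for inhibition of lysosomal alpha-glucosidase (Rattus norvegicus), read by colorimetric assay; a lower number here means a stronger inhibitor, a higher number a weaker inhibitor. Compound 1 `OC[C@@]1(c2ccc(O)cc2)NC[C@@H](O)[C@@H]1O` gives 11000 nM. Compound 2 `Cc1ccc([C@@]2(CO)NC[C@H](O)[C@H]2O)cc1` gives 17000 nM. Among the compounds with values here, compound 3 `COc1ccc([C@@]2(CO)NC[C@H](O)[C@H]2O)cc1` gives 2100 nM, the lowest of the three numbers, and the one measured step, an 8.1-fold lower number from compound 2 to compound 3 (0.91 log units; beyond the scatter), shows that putting a methoxy in place of a methyl on the aromatic ring lowers the number by a modest amount that lies beyond the scatter.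

Compound 4 `OC[C@]1(c2ccc(O)cc2)NC[C@H](O)[C@H]1O` is the next step from compound 3: hydrogen in place of methyl on an oxygen on an aromatic ring. Within the data shown here, no measured step covers the loss of a methyl from an aromatic oxygen, so the step from compound 2 to compound 3 bears only indirectly, and the value of compound 1, which also carries a hydroxy on its aromatic ring, is the closest guide. On that basis a higher number than compound 3 is expected for compound 4, with the step of a 3.3-fold higher number from compound 3 to compound 4 (0.52 log units; beyond the scatter) estimated, and compound 4 is estimated at 7000 nM, within a range from 2500 nM to 20000 nM.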

Compound 4, half-maximal inhibitory concentration: 2600 nM
Estimate against measurement, compound 4: 2.7-fold (0.43 log units) above; the range from low to high includes it.
By their numbers in this assay, from the lowest: compounds 3 and 4 (each within the scatter of the next); then compounds 1 and 2 (each within the scatter of the next).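

Taking the methyl off the aromatic oxygen gives a 1.2-fold higher number from compound 3 to compound 4 (0.09 log units; within the scatter) in this assay, so methoxy and hydroxy cannot be told apart at this position. Putting hydroxy in place of the methyl on the aromatic carbon gives a 6.5-fold lower number from compound 2 to compound 4 (0.82 log units; beyond the scatter), so the lower number goes with an oxygen at this place whether or not it carries a methyl, which an 8.1-fold lower number from compound 2 to compound 3 (0.91 log units; beyond the scatter) had shown for methoxy alone. The same hydroxy group in the mirror-image form gives a 4.2-fold lower number from compound 1 to compound 4 (0.63 log units; beyond the scatter), a gap that comes down to arrangement in space alone: the fact that compounds 1 and 4 differ only in the configuration as drawn.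

Going by these compounds, it remains open whether a longer chain on that oxygen, such as ethyl or benzyl, or an amine in its place, would keep the number this low. Also open, on these data alone, is whether the mirror-image forms of compound 2 and compound 3 would show a similar gap.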